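Methoxycarbonyl in place of fluoro in compound 2

The source may report more compounds than this note shows. Statements on the series, on what has been measured and on what is new or still open speak of the compounds shown alone.

Compound 1 `CSc1ccc(NC(=O)Nc2cc(C)nc3ccccc23)cc1` - 24000 nM
Compound 2 `Cc1cc(NC(=O)Nc2ccc(F)cc2)c2ccccc2n1` - > 25000 nM

Compound 2 reads > 25000 nM in an ADME assay on HEK293 cells (Homo sapiens) for cytotoxicity, with a stated time of 72 h (a higher number here means that more compound is needed for the effect, a lower number that less compound is needed), and that value is a limit, not a number. Compound 3 `COC(=O)c1ccc(NC(=O)Nc2cc(C)nc3ccccc23)cc1` is not yet measured. It carries methoxycarbonyl in place of fluoro on an aromatic carbon, para to a large group methoxycarbonyl in place of fluoro on an aromatic carbon and shares the rest of its structure with compound 2. Among the compounds with values here, the only measured step that bears on this is an at least 1.0-fold higher number from compound 1 to compound 2 (0.01 log units; that floor lies within the scatter) and its floor lies within the scatter. Going by these compounds, that step ends at the limit of > 25000 nM in this assay, at which 1 of the 2 values shown sits, and so its true size remains open. Within the data shown here, compound 1 gives 24000 nM and this is the one numerical value so far. The expected step is an at least 1.1-fold lower number from compound 2 to compound 3 (0.05 log units; that floor lies within the scatter) and no change beyond the scatter is expected in this assay in either direction. The estimate for compound 3 is 22000 nM within an expected range from 10000 nM to 25000 nM and a report at the limit is quite possible.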

Compound 3, half-maximal effective concentration: 15000 nM
Compound 3: the middle estimate sits 1.5-fold (0.17 log units) above what was measured, and the stated range covers the measured number.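

In this assay, methoxycarbonyl in place of fluoro on the aromatic carbon para to a large group gives an at least 1.6-fold lower number from compound 2 to compound 3 (0.22 log units; that floor lies within the scatter), so even the smallest step this allows does not clear the usual scatter. Set against methylsulfanyl at the same place, methoxycarbonyl gives a 1.6-fold lower number from compound 1 to compound 3 (0.20 log units; within the scatter), which means that these two groups cannot be told apart in this assay, although the entering group brings hydrogen-bond acceptors. Going by these compounds, compound 2 stands at a limit and not at a number, so the true size of the step from fluoro remains open: the limit of > 25000 nM in this assay, at which 1 of the 3 values shown sits.

The compounds shown leave open whether a carboxylic acid or an amine at this aromatic carbon would read like methoxycarbonyl. They also do not tell whether a longer chain on the ester oxygen would shift the number beyond the scatter.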